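Replacing the Aminophenyl Ketone with a Difluorophenyl Ring

The source may hold more compounds than are shown below. What is called first, only, known or untested is meant among the compounds shown, and "the series" means these compounds.

compound 1 `COc1cc(-c2cc(/C=C/C(=O)c3ccc(N)cc3)[nH]n2)cc(OC)c1OC`: 106%
compound 2 `COc1ccc(C(=O)/C=C/c2cc(-c3cc(OC)c(OC)c(OC)c3)n[nH]2)cc1OC`: 89%

In a functional assay on SF-268 cells (Homo sapiens) for cytotoxicity, read by sulforhodamine B assay, with a stated time of 48 h, tested at 0.1 uM (a higher number here means a weaker effect of the compound at the concentration tested, a lower number a stronger effect), compound 1 gives the highest of the two numbers, with compound 2 nearest. Compound 3 is `COc1cc(-c2cc(/C=C/C(=O)c3ccc(F)c(F)c3)[nH]n2)cc(OC)c1OC`. It differs from compound 1 in one place: 3,4-difluorophenyl in place of 4-aminophenyl on a carbonyl carbon. Within the data shown here, the only measured step at this carbonyl carbon, a number 17 percentage points lower from compound 1 to compound 2 (beyond the scatter), swapped the same 4-aminophenyl for another ring and lowered the number beyond the scatter, so a second swap at the same place may move the same way, though no measured compound carries a 3,4-difluorophenyl. Compound 3 is therefore expected to give about 95%, within 78% to 110%. The expected step is a number 11 percentage points lower from compound 1 to compound 3 (beyond the scatter).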

Compound 3, a percentage reported as activity, at one concentration (the size of the read-out at that concentration, not a potency): 94%
Estimate against measurement, compound 3: 1 percentage points above, and the stated range covers the measured number.
By their numbers in this assay, from the lowest: compounds 2 and 3 (each within the scatter of the next); then compound 1.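

In this assay, a second ring on the carbonyl carbon also lowers the number (a number 12 percentage points lower from compound 1 to compound 3 (beyond the scatter)), so among the compounds shown the drop does not belong to 3,4-dimethoxyphenyl alone. The two replacement rings cannot be told apart (a number 5 percentage points higher from compound 2 to compound 3 (within the scatter)), although one carries two fluorine atoms and the other two methoxy groups. Nothing available explains why leaving 4-aminophenyl shifts the number. Still open, going by these compounds, is whether an unsubstituted phenyl, a 4-hydroxyphenyl or a pyridine ring on this carbonyl carbon would lower the number further.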